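A few compounds are considered here, and "the series" means these few. Any claim that something is new, unique, unknown or untested is made for them only; others in the source may bear on it.

Going by the values given here, compound 2 `CCN(CC)CCCNC(=O)c1ccc(C(CC)(CC)c2ccc(OCC(O)C(C)(C)C)c(C)c2)n1CC` gives 66 nM in an assay on HL-60 cells for agonist activity at vitamin D3 receptor (Homo sapiens), read by microscopy, with a stated time of 96 h (a higher number here means that more compound is needed for the effect, a lower number that less compound is needed), the second highest of the three numbers known, with compound 1 `CCN(CC)CCCNC(=O)c1ccc(C(CC)(CC)c2ccc(OCC(=O)C(C)(C)C)c(C)c2)n1CC` at 22 nM and compound 3 `CCn1c(C(=O)N(C)CC(=O)O)ccc1C(CC)(CC)c1ccc(OCC(=O)C(C)(C)C)c(C)c1` at 1390 nM. Compound 4 `CC[C@@H](C)[C@H](NC(=O)c1ccc(C(CC)(CC)c2ccc(OCC(O)C(C)(C)C)c(C)c2)n1CC)C(=O)O` differs from compound 2 in one place: 1-carboxy-2-methylbutyl in place of 3-(diethylamino)propyl on an amide-type nitrogen. Among the compounds with values here, the one measured step that bears on this replaces the same amine-bearing chain with a carboxylic acid group at the amide, and it was large: a 63-fold higher number from compound 1 to compound 3 (1.80 log units; beyond the scatter). A step of a similar kind, upward in the number, is therefore expected here; the estimated step is a 30-fold higher number from compound 2 to compound 4 (1.48 log units; beyond the scatter). Compound 4 is thus expected to give about 2000 nM, with a range from 500 nM to 8000 nM.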

Compound 4, half-maximal effective concentration: 2.3 nM
Compound 4: the middle estimate sits 870-fold (2.94 log units) above what was measured; the measured number lies below the stated range.
By their numbers in this assay, from the lowest: compound 4; then compound 1; then compound 2; then compound 3.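

At this amide-type nitrogen, a chain carrying a carboxylic acid can lower the number: putting 1-carboxy-2-methylbutyl in place of 3-(diethylamino)propyl gives a 29-fold lower number from compound 2 to compound 4 (1.46 log units; beyond the scatter). The earlier change to a carboxylic acid-bearing group went the other way, with a 63-fold higher number from compound 1 to compound 3 (1.80 log units; beyond the scatter), so the presence of the acid alone does not set the direction across these compounds. Nothing available explains this reversal. Still open, on these data alone, is whether the 1-carboxy-2-methylbutyl chain gives the same gain on the ketone-bearing compound 1. Also open, as far as these compounds go, is whether a methyl ester could replace its carboxylic acid.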